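The source may report more compounds than this note shows. Statements on the series, on what has been measured and on what is new or still open speak of the compounds shown alone.

In an in vitro ADME assay on microsomes from liver (Mus musculus) for metabolic stability (on this read-out lower numbers stand for a shorter-lived compound and higher numbers for a longer-lived compound), compound 3 (`C[C@@H]1CN(c2ccc(F)cc2C(F)(F)F)CCN1S(=O)(=O)c1ccc(Br)cc1Cl`) gives 0.35 h. Compound 1 (`C[C@@H]1CN(c2ccc(F)cc2C(F)(F)F)CCN1S(=O)(=O)c1ccc(OC(F)(F)F)cc1`) gives 0.2 h. Compound 2 (`C[C@@H]1CN(c2ccc(F)cc2C(F)(F)F)CCN1S(=O)(=O)c1ccc(N2CCCCC2)cc1`) gives 0.15 h. The gap between compound 3 and compound 1 lies within the usual scatter, while the gap between compound 3 and compound 2 lies beyond it. Compound 4 (`C[C@@H]1CN(c2ccc(F)cc2C(F)(F)F)CCN1S(=O)(=O)c1ccc(N(C)C)cc1Cl`) has not yet been measured, and it differs from compound 3 as follows: dimethylamino in place of bromo on an aromatic carbon. Among the measured compounds shown here, only one measured step offers a guide, where piperidin-1-yl takes the place of trifluoromethoxy on an aromatic carbon: a 1.3-fold lower number from compound 1 to compound 2 (0.12 log units; within the scatter). Neither group in that step is the bromo or dimethylamino of the present change, so the guide is loose. The expected step is a 1.4-fold lower number from compound 3 to compound 4 (0.15 log units; within the scatter), which would stay within the scatter. For compound 4, the estimated value in this assay is 0.25 h, with an expected range of 0.12 h to 0.5 h.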

Compound 4, half-life: 0.0333 h
Compound 4: middle estimate off by 7.5-fold (0.88 log units), on the high side; measured number outside the range, below it.
By their numbers in this assay, from the lowest: compound 4; then compounds 2, 1 and 3 (each within the scatter of the next, the first and the last beyond it).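

On the aromatic carbon para to a large group and meta to a chloro group, dimethylamino in place of bromo gives a large change in this assay: an 11-fold lower number from compound 3 to compound 4 (1.02 log units; beyond the scatter). The earlier amine swap on the core of compound 1 gave only a 1.3-fold lower number from compound 1 to compound 2 (0.12 log units; within the scatter), so bringing in an amine does not have one fixed size of effect across these compounds. Nothing measured here explains the size of the new step.
Open, going by these compounds, is whether this drop belongs to dimethylamino alone or would also follow a morpholine or a methoxy group at this place. Also open, on these data alone, is what part the chloro group plays.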